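Moving the carboxyl on the benzyl group of compound 2

The compounds below may be only part of what the source reports. "The series", "measured", "known", "first", "only" and "open" are said of these compounds alone.

Compound 2 `COc1cc(C(=O)O)ccc1CN1CCC[C@H](OCc2cc(Cl)cc(Cl)c2)[C@@H]1c1ccccc1` holds the only number shown in an assay on isolated protein for activation of cGMP-dependent protein kinase 1 (Homo sapiens), read by ADP-Glo, with stated times of 120 min and 40 min; a higher number here means that more compound is needed for the effect, a lower number that less compound is needed: compound 2 gives 62000 nM. Compound 1 `CN1CCC[C@H](OCc2cc(Cl)cc(Cl)c2)[C@@H]1c1ccccc1` reports only a limit of > 200000 nM there. The step of an at least 3.2-fold lower number from compound 1 to compound 2 (0.50 log units; beyond the scatter) is thus bounded by the limit of > 200000 nM in this assay, at which 1 of the 2 values shown sits. Compound 3 `COc1ccc(C(=O)O)cc1CN1CCC[C@H](OCc2cc(Cl)cc(Cl)c2)[C@@H]1c1ccccc1` differs from compound 2 by 5-carboxy-2-methoxyphenyl in place of 4-carboxy-2-methoxyphenyl on a saturated chain carbon bound to an amine nitrogen in a ring. Going by the values given here, no measured step moves the carboxyl around the ring; the single measured step concerns adding the whole group and speaks only loosely to this change. Compound 3 is therefore expected to give about 80000 nM, between 25000 nM and 250000 nM, a step of a 1.3-fold higher number from compound 2 to compound 3 (0.11 log units; within the scatter) that need not exceed the scatter.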

Compound 3, half-maximal effective concentration: 123000 nM
The estimate for compound 3 lay 1.5-fold (0.19 log units) below the measured number, within the range that was stated.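

In this assay, exchanging 4-carboxy-2-methoxyphenyl for 5-carboxy-2-methoxyphenyl gives a 2.0-fold higher number from compound 2 to compound 3 (0.30 log units; within the scatter), so these two placements of the carboxyl cannot be told apart here. The other new step, an at least 1.6-fold lower number from compound 1 to compound 3 (0.21 log units; that floor lies within the scatter), has a floor that does not clear the scatter, so it does not itself establish a difference. That step is bounded by a limit of the assay: the limit of > 200000 nM in this assay, at which 1 of the 3 values shown sits.

From the compounds shown here alone, whether a primary amide or a tetrazole in place of the carboxylic acid would change the number stays open. So does the effect of hydrogen in place of the methoxy group.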